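The source may report more compounds than this note shows. Statements on the series, on what has been measured and on what is new or still open speak of the compounds shown alone.

Compound 1 `CC(C)=CC(=O)Nc1c(C(O)(C(F)(F)F)C(F)(F)F)ccc2ccccc12` gives 46 nM in an assay on LtK cells with ATP-sensitive inward rectifier potassium channel 11 (Homo sapiens) as the target; on this read-out higher numbers stand for an effect only at larger amounts of compound and lower numbers for an effect already at smaller amounts.
Compound 2 `Cc1cccc(C(=O)Nc2c(C(O)(C(F)(F)F)C(F)(F)F)ccc3ccccc23)c1` gives 23 nM.
Compound 3 `O=C(Nc1c(C(O)(C(F)(F)F)C(F)(F)F)ccc2ccccc12)c1ccc(F)cc1` gives 70 nM.

Among these three, compound 3 carries the highest number: a 1.5-fold higher number from compound 1 to compound 3 (0.18 log units; within the scatter), and a 3.0-fold higher number from compound 2 to compound 3 (0.48 log units; beyond the scatter). Compound 4 `O=C(Nc1c(C(O)(C(F)(F)F)C(F)(F)F)ccc2ccccc12)c1cccnc1` differs from compound 3 in one place: pyridin-3-yl in place of 4-fluorophenyl on a carbonyl carbon. For the measured compounds named here, no measured step exchanges a ring of carbon only for one with a hetero atom on this carbonyl carbon, so nothing directly speaks to this change. The steps that do alter the group on the carbonyl carbon, a 2.0-fold lower number from compound 1 to compound 2 (0.30 log units; within the scatter) and a 3.0-fold higher number from compound 2 to compound 3 (0.48 log units; beyond the scatter), are small to modest in size. The step expected for compound 4 is therefore no change at the digits printed from compound 3 to compound 4 (within the scatter), with nothing beyond the scatter anticipated in either direction. The estimate for compound 4 in this assay is 70 nM, with a range from 25 nM to 200 nM.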

Compound 4, half-maximal effective concentration: 60 nM
The estimate for compound 4 lay 1.2-fold (0.07 log units) above the measured number, within the range that was stated.
By their numbers in this assay, from the lowest: compounds 2, 1, 4 and 3 (each within the scatter of the next, the first and the last beyond it).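

Pyridin-3-yl, a ring with a hetero atom and a hydrogen-bond acceptor, is tolerated on this carbonyl carbon in place of 4-fluorophenyl, with a 1.2-fold lower number from compound 3 to compound 4 (0.07 log units; within the scatter) as the step. Set against 2-methylprop-1-en-1-yl, it gives a 1.3-fold higher number from compound 1 to compound 4 (0.12 log units; within the scatter) and again stays within the scatter, but against 3-methylphenyl it gives a 2.6-fold higher number from compound 2 to compound 4 (0.42 log units; beyond the scatter) and stands clearly apart. Nothing available explains these numbers.

Pyridin-2-yl and pyridin-4-yl leave open whether the place of the ring nitrogen matters. A carboxylic acid or an amine on this ring is also an open case.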